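Acetoxymethyl enones: phenyl replacing pentan-3-yl at the alkene

This account rests on a few compounds, and the source may have more. Where it says the series, first, only, none or still open, it means among the compounds named here.

Measured so far in a functional assay on HBL-100 cells (Homo sapiens) for inhibition, read by sulforhodamine B assay, with a stated time of 48 h; a higher number here means a weaker inhibitor of growth, a lower number a stronger inhibitor of growth:
- compound 1 `O=C(/C(=C/c1ccccc1)CCl)c1ccccc1` gives 12000 nM.
- compound 2 `CC(=O)OC/C(=C\C1CCCCC1)C(=O)c1ccccc1` gives 21000 nM.
- compound 3 `CCC(/C=C(\COC(C)=O)C(=O)c1ccccc1)CC` gives only > 100000 nM, a limit of the assay and not a number.

Compound 3 thus stands at the weak end of the three, the only one sitting at the limit (the limit of > 100000 nM in this assay, at which 1 of the 3 values shown sits). Compound 4 `CC(=O)OC/C(=C\c1ccccc1)C(=O)c1ccccc1` is compound 3 with phenyl in place of pentan-3-yl on a double-bonded chain carbon bound to a double-bonded chain carbon. Within the data shown here, the one measured step at this place is an at least 4.7-fold higher number from compound 2 to compound 3 (0.67 log units; beyond the scatter), where the ring was exchanged for the open pentan-3-yl chain and growth inhibition fell beyond the scatter. The change to compound 4 returns a ring at the same place, and compound 1, which already carries phenyl there, gives 12000 nM, close to compound 2 with cyclohexyl. The step from compound 3 to compound 4 is therefore expected to run downward, estimated as an at least 5.0-fold lower number from compound 3 to compound 4 (0.69 log units; beyond the scatter). For compound 4 in this assay the estimate is 20000 nM, expected to fall between 7000 nM and 60000 nM.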

Compound 4, concentration for 50% growth inhibition: 17000 nM
For compound 4 the middle estimate is 1.2-fold (0.07 log units) above the measured one; the measured number falls inside the stated range.
By their numbers in this assay, from the lowest: compounds 1, 4 and 2 (each within the scatter of the next). At a limit, above all of these: compound 3.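

In this assay, an at least 5.8-fold lower number from compound 3 to compound 4 (0.76 log units; beyond the scatter), so phenyl restores at this place the growth inhibition that was lost with pentan-3-yl, and the loss is now seen in both directions of exchange. Phenyl and cyclohexyl on the double-bonded chain carbon cannot be told apart, with a 1.2-fold lower number from compound 2 to compound 4 (0.09 log units; within the scatter), and the same holds for acetoxy and chloro on the saturated chain carbon, with a 1.4-fold higher number from compound 1 to compound 4 (0.15 log units; within the scatter). The reading for compound 3 is a limit of the assay and not a number, so the size of the change stays open on one side: the limit of > 100000 nM in this assay, at which 1 of the 4 values shown sits.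

Whether the loss belongs to open chains in general or to pentan-3-yl alone remains undecided, as a straight butyl chain at this place would test. Also open, going by these compounds, is whether a ring carrying nitrogen, such as pyridyl, would behave like phenyl and cyclohexyl.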